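The compounds below may be only part of what the source reports. "The series", "measured", "known", "first", "only" and "open" are said of these compounds alone.

Measured in a functional assay on the whole organism (strain Wistar) for inhibition, with Rattus norvegicus as the target, read by paw edema, with stated times of 60 min and 4 h, at a dose of 100 mg/kg by the oral route; a lower number here means less inhibition, a higher number more inhibition at the dose given (going by the name of the read-out):
compound 1 `CNC(=O)CC1CCc2cc(OC)c(OC)cc21`: 29.7%
compound 2 `CCCNC(=O)CC1CCc2cc(OC)c(OC)cc21`: 26.6%
compound 3 `COc1cc2c(cc1OC)C(CC(=O)NC(C)(C)C)CC2`: 32.8%

Compound 2 stands at the low end of these three numbers, but a number 3.1 percentage points lower from compound 1 to compound 2 (within the scatter) and a number 6.2 percentage points higher from compound 2 to compound 3 (within the scatter) are both within the scatter, as is a number 3.1 percentage points higher from compound 1 to compound 3 (within the scatter), so the three amides are not separated by this assay.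

Compound 4 `COc1cc2c(cc1OC)C(CC(=O)NCc1ccccc1)CC2` is the next member: phenyl in place of ethyl on a saturated chain carbon bound to an amide-type nitrogen. Among the measured compounds shown here, no measured step trades a chain for an aromatic ring at this place; the steps that bear on it are the three changes of the group on the amide nitrogen, all within the scatter. The expected step is therefore a number 3.4 percentage points higher from compound 2 to compound 4 (within the scatter), none beyond the scatter. For compound 4 in this assay the estimate is 30%, within a range of 18% to 42%.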

Compound 4, a percentage reported as inhibition, in the whole organism at one dose (the size of the read-out at that dose, not a potency): 18.8%
Compound 4: middle estimate off by 11.2 percentage points, on the high side, within the range that was stated.
By their numbers in this assay, from the lowest: compounds 4, 2, 1 and 3 (each within the scatter of the next, the first and the last beyond it).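

In this assay the only separations among the compounds shown come with the benzyl group on the amide nitrogen: a number 14 percentage points lower from compound 3 to compound 4 (beyond the scatter) and a number 10.9 percentage points lower from compound 1 to compound 4 (beyond the scatter), while a number 7.8 percentage points lower from compound 2 to compound 4 (within the scatter) leaves the benzyl and propyl amides unseparated. This position therefore responds to some changes, but the aromatic ring is not set apart from every chain. No evidence on the cause of this result is available. Going by these compounds, whether a longer chain ending in phenyl, or an amine or carboxylic acid on the benzyl ring, would read like compound 4 stays open.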